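The source may report more compounds than this note shows. Statements on the series, on what has been measured and on what is new or still open speak of the compounds shown alone.

Measured compounds in a functional assay on MDA-MB-231 cells (Homo sapiens) for cytotoxicity, read by sulforhodamine B assay, with a stated time of 48 h; on this read-out higher numbers stand for weaker inhibition of growth and lower numbers for stronger inhibition of growth:

- Compound 1, `CCN(CC)CN1C(=O)/C(=N\c2nc3ccc(C)cc3s2)c2ccccc21`: 32700 nM
- Compound 2, `Cc1ccc2nc(/N=C3\C(=O)N(CN4CCCCC4)c4cccc(Br)c43)sc2c1`: 38300 nM
- Compound 3, `CCN(CC)CN1C(=O)/C(=N\c2nc3ccc(C)cc3s2)c2c(Cl)cccc21`: 20400 nM

Compound 3 has the lowest of the three numbers in this assay, but its neighbours lie close: the step of a 1.6-fold lower number from compound 1 to compound 3 (0.20 log units; within the scatter) stays within the scatter, and the value of compound 2 sits within the scatter of compound 3 as well. All three compounds therefore read as roughly alike in this assay.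

Compound 4, `Cc1ccc2nc(/N=C3\C(=O)N(CN4CCCCC4)c4cccc(Cl)c43)sc2c1`, is the next compound to be tested. It differs from compound 3 in one place: piperidin-1-yl in place of diethylamino on a saturated chain carbon bound to an amide-type nitrogen in a ring. Going by the values given here, only one measured step is at hand, and it concerns a different change, the chloro in place of hydrogen that separates compound 1 from compound 3. Compound 2 carries the piperidin-1-yl group, and its value shows no separation from the others beyond the scatter. On that basis the step of a 1.5-fold higher number from compound 3 to compound 4 (0.17 log units; within the scatter) is expected to be small, with no direction beyond the scatter. Compound 4 is thus estimated at 30000 nM, within a range from 12000 nM to 75000 nM.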

Compound 4, concentration for 50% growth inhibition: 55800 nM
Compound 4: the middle estimate sits 1.9-fold (0.27 log units) below what was measured; low and high end bracket the measured number.
By their numbers in this assay, from the lowest: compounds 3, 1, 2 and 4 (each within the scatter of the next, the first and the last beyond it).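

In this assay, going by these compounds alone, putting piperidin-1-yl in place of diethylamino gives a 2.7-fold higher number from compound 3 to compound 4 (0.44 log units; beyond the scatter) and is the first step in this set to lie beyond the scatter, so the number does respond, modestly, to the amine carried on this saturated chain carbon. The halogen on the aromatic carbon shows no such separation: chloro in place of bromo gives a 1.5-fold higher number from compound 2 to compound 4 (0.16 log units; within the scatter) and stays within the scatter.

The compounds shown leave open how a morpholin-4-yl or pyrrolidin-1-yl group would read at this place. They also leave open whether the same amine change gives a similar step with bromo or hydrogen on the aromatic carbon. No measurement at hand explains why the piperidin-1-yl compound gives the higher number.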